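Chalcone-bearing amide in a thiocarbamate lactone series

The source may report more compounds than this note shows. Statements on the series, on what has been measured and on what is new or still open speak of the compounds shown alone.

Compounds measured so far:
compound 1, `O=C(CSC(=S)N[C@H]1CCOC1=O)Nc1ccccc1F`: > 128000 nM
compound 2, `Cc1ccc(NC(=O)CSC(=S)N[C@H]2CCOC2=O)cc1`: 32700 nM

In a functional assay on SMMC-7721 cells (Homo sapiens) for cytotoxicity, read by MTT assay, with a stated time of 72 h (on this read-out lower numbers stand for stronger inhibition and higher numbers for weaker inhibition), compound 1 gives only a limit, > 128000 nM, at the limit of > 128000 nM in this assay, at which 1 of the 2 values shown sits. For the measured compounds named here, compound 2 gives 32700 nM in this assay, the only number in the set, so compound 2 stands alone as the reference. Going by the values given here, the single measured step, an at least 3.9-fold lower number from compound 1 to compound 2 (0.59 log units; beyond the scatter), shows that changing the aryl group on the amide-type nitrogen can move the number beyond the scatter.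

Compound 3, `O=C(CSC(=S)N[C@H]1CCOC1=O)Nc1ccc(C(=O)/C=C/c2ccccc2)cc1`, differs from compound 2 by (2-phenylethenyl)carbonyl in place of methyl on an aromatic carbon. Among the compounds with values here, no measured step covers this change; the step from compound 1 to compound 2 concerns a different substituent, so it gives only loose guidance. A modest move toward stronger inhibition is expected, a 4.1-fold lower number from compound 2 to compound 3 (0.61 log units; beyond the scatter), with wide uncertainty. Compound 3 is estimated at 8000 nM, within 2000 nM to 40000 nM.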

Compound 3, half-maximal inhibitory concentration: > 128000 nM
Compound 3: no number, only a limit (the forecaster's own chance of this, stated with the estimate: 10%); middle value at least 16-fold (1.20 log units) from the limit.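

In this assay, putting (2-phenylethenyl)carbonyl in place of methyl on the aromatic carbon para to a large group gives an at least 3.9-fold higher number from compound 2 to compound 3 (0.59 log units; beyond the scatter), so at this position the change brings no gain over methyl. Compound 3 gives only a limit, > 128000 nM. Compound 2 therefore remains the only compound with a measured number, and the other values shown are limits: the limit of > 128000 nM in this assay, at which 2 of the 3 values shown sit.

The compounds shown leave open whether an amine, a carboxylic acid or a methoxy group at this position would keep or lower the number of compound 2. They also leave open whether the change at compound 3 follows from the carbonyl, the double bond or the added aromatic ring of the (2-phenylethenyl)carbonyl group.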